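The compounds below may be only part of what the source reports. "The series", "measured", "known", "first", "only" and "open" are said of these compounds alone.

Measured compounds:
compound 1, `COc1ccccc1CNC(=O)c1c(-c2ccccc2C)c2ccccc2c(=O)n1C`: 470 nM
compound 2, `COc1ccccc1CN(C)C(=O)Nc1c(-c2ccccc2)c2cc(C)c(C)cc2c(=O)n1C`: 23 nM
compound 3, `Cc1cc2c(-c3ccccc3)c(NC(=O)N(C)Cc3ccccc3Cl)n(C)c(=O)c2cc1C`: 4.2 nM

In an assay on IM-9 cells for binding affinity to Substance-P receptor (Homo sapiens) (a higher number here means a weaker inhibitor, a lower number a stronger inhibitor), compound 3 holds the lowest number of the three, with compound 2 nearest at a step of a 5.5-fold lower number from compound 2 to compound 3 (0.74 log units; beyond the scatter) and compound 1 furthest away. The next compound, compound 4 `Cc1cc(C)cc(CN(C)C(=O)Nc2c(-c3ccccc3)c3cc(C)c(C)cc3c(=O)n2C)c1`, keeps the shared core of compound 3 and alters only the benzyl group: 3,5-dimethylphenyl in place of 2-chlorophenyl on a saturated chain carbon bound to an amide-type nitrogen. Among the compounds with values here, only one measured step touches this region, the change from compound 2 to compound 3, where a single substituent on the aromatic ring of the benzyl group gave a modest drop in the number. Within the data shown here, no measured pair shows what removing that substituent and placing two methyl groups elsewhere on the ring does, so the direction cannot be read off directly. A modest move in this assay in either direction is plausible; a small rise from compound 3 is expected, giving a 2.4-fold higher number from compound 3 to compound 4 (0.38 log units; beyond the scatter). For compound 4 the estimated value is 10 nM, with a range of 2.5 nM to 40 nM.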

Compound 4, half-maximal inhibitory concentration: 28 nM
Compound 4: the middle estimate sits 2.8-fold (0.45 log units) below what was measured, and the stated range covers the measured number.
By their numbers in this assay, from the lowest: compound 3; then compounds 2 and 4 (each within the scatter of the next); then compound 1.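

In this assay the benzyl group now carries a third variant on the same core, and 3,5-dimethylphenyl in place of 2-chlorophenyl gives a 6.7-fold higher number from compound 3 to compound 4 (0.82 log units; beyond the scatter) and so goes against the gain seen in a 5.5-fold lower number from compound 2 to compound 3 (0.74 log units; beyond the scatter). The 3,5-dimethylphenyl and 2-methoxyphenyl groups cannot be told apart here, with a 1.2-fold higher number from compound 2 to compound 4 (0.09 log units; within the scatter), so of these three groups only 2-chlorophenyl separates from the others at this place. Nothing available here accounts for this difference.

The compounds shown leave open whether the lower number of compound 3 belongs to the chlorine itself or to where it sits on the ring. Going by these compounds, how a plain phenyl, 2-fluorophenyl or 3,5-dichlorophenyl would compare on the same saturated chain carbon also remains open.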